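Methyl in place of chloro on an inactive parent

The compounds below may be only part of what the source reports. "The series", "measured", "known", "first", "only" and "open" are said of these compounds alone.

Compound 1 `O=S(=O)(Nc1ccc2oc(-c3ccccc3)nc2c1)c1cccc(Cl)c1` has been tested in an assay on cells for inhibition of HSP60/HSP10 (Homo sapiens), with a stated time of 60 min (a higher number here means a weaker inhibitor, a lower number a stronger inhibitor), where compound 1 gives > 100000 nM, which is a limit of the assay and not a number. Compound 2 `C=Cc1ccc(S(=O)(=O)Nc2ccc(-c3nc4ccccc4o3)cc2)cc1` in this assay gives > 100000 nM, likewise only a limit. Both results sit at the limit of > 100000 nM in this assay, at which 2 of the 2 values shown sit, so compound 1 stands at the weak end of what has been measured, and nothing in the numbers separates compound 1 from compound 2. Among the measured compounds shown here, no step between two measured compounds can be read from this set, so no measured step size is available to carry forward.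

Compound 3 `Cc1cccc(S(=O)(=O)Nc2ccc3oc(-c4ccccc4)nc3c2)c1` is not yet measured. Against compound 1 the difference is methyl in place of chloro on an aromatic carbon, one heavy atom exchanged for one heavy atom at the same place, with the rest of the shared core untouched. With compound 1 giving only a limit in this assay, the step from compound 1 to compound 3 is expected to be none beyond the scatter, and the measured outcome for compound 3 is expected to be a limit again. Compound 3 is expected to give around 150000 nM in this assay, within a range of 50000 nM to 500000 nM. The step that the limit leaves unreadable from compound 1 to compound 3 is what is expected.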

Compound 3, half-maximal inhibitory concentration: > 100000 nM
Compound 3: no number, only a limit; the forecaster's own chance of this, stated with the estimate: 85%; the middle value is on the limit's open side.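

Among the compounds shown here, compound 3 gives only a limit, as compound 1 does, so no step between compound 1 and compound 3 can be read for methyl in place of chloro. The compounds shown leave open the size of this change, and whether any close relative of compound 1 gives a number in this assay. The results stand as follows: the limit of > 100000 nM in this assay, at which 3 of the 3 values shown sit.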